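A Cyclic Amide in Place of a Secondary Amide

This account rests on a few compounds, and the source may have more. Where it says the series, first, only, none or still open, it means among the compounds named here.

Going by the values given here, compound 1 `CCN(CC)S(=O)(=O)c1ccc(S(=O)(=O)N2CCC[C@@H](C(=O)N[C@H]3CC[C@H](OC)CC3)C2)cc1` is the weakest of the three compounds measured so far: in a functional assay on MIA PaCa-2 cells (Homo sapiens) for inhibition, read by MTT assay, with a stated time of 7 days (on this read-out lower numbers stand for stronger inhibition and higher numbers for weaker inhibition), compound 1 gives 1350 nM, the highest number of the set. Compound 3 `CCN(CC)S(=O)(=O)c1ccc(S(=O)(=O)N2CCC[C@@H](C(=O)N3CCOCC3)C2)cc1`, which carries morpholin-4-yl on the carbonyl carbon, gives 350 nM. Compound 2 `O=C([C@@H]1CCCN(S(=O)(=O)c2ccc(S(=O)(=O)N3CC[C@@H](O)C3)cc2)C1)N1CCC(F)(F)CC1` bears 4,4-difluoropiperidin-1-yl on its carbonyl carbon, though its sulfonamide end differs from compound 1 as well. Compound 2 gives 210 nM.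

The new compound 4 `CCN(CC)S(=O)(=O)c1ccc(S(=O)(=O)N2CCC[C@@H](C(=O)N3CCC(F)(F)CC3)C2)cc1` keeps the whole of compound 1 apart from one change: 4,4-difluoropiperidin-1-yl in place of (4-methoxycyclohexyl)amino on a carbonyl carbon.

Among the compounds with values here, one measured step bears directly on this change. Moving from a secondary amide to a cyclic tertiary amide gave a 3.9-fold lower number from compound 1 to compound 3 (0.59 log units; beyond the scatter), a gain beyond the scatter. Within the data shown here, compound 2 shows that a 4,4-difluoropiperidin-1-yl amide can sit on a low number, but no single-change step connects compound 2 to compound 1, so its value is only a hint. On the strength of the morpholine step, compound 4 is expected to move in the same direction, by roughly a 4.2-fold lower number from compound 1 to compound 4 (0.63 log units; beyond the scatter).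

Compound 4 is therefore estimated at 320 nM, with a likely range from 130 nM to 750 nM.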

Compound 4, half-maximal inhibitory concentration: 16 nM
The estimate for compound 4 lay 20-fold (1.30 log units) above the measured number, and the stated range ends above it.
By their numbers in this assay, from the lowest: compound 4; then compounds 2 and 3 (each within the scatter of the next); then compound 1.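

In this assay the position on the carbonyl carbon proves far more sensitive than the morpholine result suggested: closing the amide into a ring and losing the amide hydrogen does not set the outcome alone, as two cyclic amides on the same core differ by a 22-fold lower number from compound 3 to compound 4 (1.34 log units; beyond the scatter) with 4,4-difluoropiperidin-1-yl in place of morpholin-4-yl. Measured against the secondary amide, the full change gives an 84-fold lower number from compound 1 to compound 4 (1.93 log units; beyond the scatter) and is a large step, whereas the morpholine step was only modest. The other end of the molecule also counts, since with the 4,4-difluoropiperidin-1-yl amide held fixed, diethylamino in place of 3-hydroxypyrrolidin-1-yl on a sulfonyl sulfur gives a 13-fold lower number from compound 2 to compound 4 (1.12 log units; beyond the scatter) and shows that the value of compound 2 did not reveal how low this amide could go.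

Nothing among the data given accounts for the size of these steps. As far as these compounds go, whether the fluorine atoms are needed remains open, and the unsubstituted piperidin-1-yl amide, the 4-fluoropiperidin-1-yl amide and the 3,3-difluoropyrrolidin-1-yl amide on the core of compound 4 would be the direct comparisons.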